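The source may report more compounds than this note shows. Statements on the series, on what has been measured and on what is new or still open speak of the compounds shown alone.

Measured in an ADME assay on Vero cells (Chlorocebus sabaeus) for cytotoxicity, read by MTT assay; a higher number here means that more compound is tolerated, a lower number that less compound is tolerated:
- compound 1 `COC(=O)c1ccccc1-n1nc(C(F)(F)F)cc1C(=O)Nc1ccc(S(=O)(=O)N2CCCC2)cc1`: "not determined" (no result reported)
- compound 2 `Cn1nc(C(F)(F)F)cc1C(=O)Nc1ccc(S(=O)(=O)N2CCC[C@H]2C(=O)O)cc1`: > 300000 nM
- compound 3 `Cn1nc(C(F)(F)F)cc1C(=O)Nc1ccc(S(=O)(=O)N2CCC(NC(=O)OC(C)(C)C)CC2)cc1`: > 300000 nM

Compound 2 has no exact value in this assay: its > 300000 nM is a limit of the assay and not a number. The entry for compound 3, > 300000 nM, is also a limit. Compound 1 offers no comparison, since its entry reads "not determined" (no result reported). For the measured compounds named here, the series therefore provides (the limit of > 300000 nM in this assay, at which 2 of the 3 values shown sit), and no step between measured compounds is available.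

Compound 4 `Cn1nc(C(F)(F)F)cc1C(=O)Nc1ccc(S(=O)(=O)N2CCNCC2)cc1` carries piperazin-1-yl in place of 2-carboxypyrrolidin-1-yl on a sulfonyl sulfur.

Going by the values given here, with no measured step to calibrate this change, the expected step, an at least 1.3-fold lower number from compound 2 to compound 4 (0.13 log units; that floor lies within the scatter), is none beyond the scatter. The expectation rests on (the limit of > 300000 nM in this assay, at which 2 of the 3 values shown sit), and a true number just under the limit remains possible. For compound 4 the estimated value in this assay is 220000 nM, with an expected range of 80000 nM to 300000 nM.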

Compound 4, half-maximal cytotoxic concentration: 126000 nM
Compound 4: middle estimate off by 1.7-fold (0.24 log units), on the high side; the range from low to high includes it.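

In this assay, for the compounds shown here, compound 4 is the first compound of the series to give a number and not a limit, so the group on the sulfonyl sulfur can bring the read-out inside the measurable range. Piperazin-1-yl in place of 2-carboxypyrrolidin-1-yl at this place gives an at least 2.3-fold lower number from compound 2 to compound 4 (0.37 log units; beyond the scatter). The step is a floor and not a full size because its starting point is a limit: the limit of > 300000 nM in this assay, at which 2 of the 4 values shown sit.

The change replaces the whole ring with its substituent, so the compounds shown do not separate the loss of the carboxylic acid from the gain of the second ring nitrogen. As far as these compounds go, how morpholin-4-yl or 4-methylpiperazin-1-yl on the sulfonyl sulfur would read in this assay stays open.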